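From cyclopropyl to thiophene on the shared core

The compounds below may be only part of what the source reports. "The series", "measured", "known", "first", "only" and "open" are said of these compounds alone.

Compound 3 `c1ccc(-n2cc3cnc(C4CC4)cc3n2)cc1` gives 69300 nM in a functional assay on MCF7 cells (Homo sapiens) for inhibition, read by fluorescence, with a stated time of 72 h (a higher number here means a weaker inhibitor of growth, a lower number a stronger inhibitor of growth), the highest of the two numbers shown. Compound 2 `c1ccc(-c2cc3nn(-c4ccccc4)cc3cn2)cc1` gives 4800 nM in this assay. Compound 1 `c1ccc(-n2cc3cnccc3n2)cc1` gives > 100000 nM, which is a limit of the assay and not a number. Compound 4 `c1ccc(-n2cc3cnc(-c4ccsc4)cc3n2)cc1` differs from compound 3 by thiophen-3-yl in place of cyclopropyl on an aromatic carbon. Among the measured compounds shown here, two measured steps bear on this change: a 14-fold higher number from compound 2 to compound 3 (1.16 log units; beyond the scatter) and an at least 20-fold lower number from compound 1 to compound 2 (1.31 log units; beyond the scatter), both large, and in each the aromatic ring sits on the side of the lower number. Thiophen-3-yl is likewise a five-membered aromatic ring, and compound 4 is therefore expected to show a large fall, a 9.9-fold lower number from compound 3 to compound 4 (1.00 log units; beyond the scatter). Compound 4 is estimated at 7000 nM, within a range from 2000 nM to 30000 nM.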

Compound 4, concentration for 50% growth inhibition: 9800 nM
Estimate against measurement, compound 4: 1.4-fold (0.15 log units) below, within the range that was stated.
By their numbers in this assay, from the lowest: compound 2; then compound 4; then compound 3. At a limit, above all of these: compound 1.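

In this assay, a five-membered aromatic ring on this carbon also gives a lower number than cyclopropyl, with a 7.1-fold lower number from compound 3 to compound 4 (0.85 log units; beyond the scatter), so the fall at this position is not confined to phenyl. The two aromatic rings are still told apart, with a 2.0-fold higher number from compound 2 to compound 4 (0.31 log units; beyond the scatter). Against hydrogen at this position the change gives an at least 10-fold lower number from compound 1 to compound 4 (1.00 log units; beyond the scatter), a step that rests on a limit of the assay and not on a number: the limit of > 100000 nM in this assay, at which 1 of the 4 values shown sits.

From the compounds shown here alone, how an amine or a longer alkyl chain on this aromatic carbon would read remains open. So does whether a substituent on the phenyl ring of compound 2 would move the number further.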